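Trimming a methoxy group from a pyrazolyl chalcone

This account rests on a few compounds, and the source may have more. Where it says the series, first, only, none or still open, it means among the compounds named here.

Measured so far:
compound 1 `COc1ccc(-c2cc(/C=C/C(=O)c3ccc(N)cc3)[nH]n2)cc1` — 98%
compound 2 `COc1cc(-c2cc(/C=C/C(=O)c3ccc(N)cc3)[nH]n2)cc(OC)c1OC` — 100%
compound 3 `COc1ccc(C(=O)/C=C/c2cc(-c3cc(OC)c(OC)c(OC)c3)n[nH]2)cc1OC` — 96%

In a functional assay on K562 cells (Homo sapiens) for cytotoxicity, read by sulforhodamine B assay, with a stated time of 48 h, tested at 0.01 uM (on this read-out higher numbers stand for a weaker effect at the one concentration tested and lower numbers for a stronger effect), compound 2 gives 100%, the highest of the three numbers, though compound 1 with 98% and compound 3 with 96% both lie within the scatter of it, so no order among the three can be claimed. For the measured compounds named here, the one step measured in one place, a number 4 percentage points lower from compound 2 to compound 3 (within the scatter), swaps the aryl group on the carbonyl carbon and stays within the scatter.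

Compound 4 `COc1ccc(-c2cc(/C=C/C(=O)c3ccc(N)cc3)[nH]n2)cc1OC` is compound 2 with one change: hydrogen in place of methoxy on an aromatic carbon. Going by the values given here, no measured step touches this aryl ring in a single place; compound 1 and compound 2 differ there in more than one place and their values differ only within the scatter. Among the compounds with values here, the only step on record, from compound 2 to compound 3, was itself within the scatter and concerns a different part of the molecule. Within the data shown here, with every number so far near the top of the scale and every step small, compound 4 is expected to sit where the others sit, and the expected step of a number 1 percentage points lower from compound 2 to compound 4 (within the scatter) is none beyond the scatter. For compound 4 in this assay the estimate is 99%, with a likely range from 92% to 104%.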

Compound 4, a percentage reported as activity, at one concentration (the size of the read-out at that concentration, not a potency): 99%
The estimate for compound 4 equals the measured number at the digits printed, within the range that was stated.
By their numbers in this assay, from the lowest: compounds 3, 1, 4 and 2 (each within the scatter of the next).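

For the compounds shown here, compound 4 gives the first steps on this aryl ring that can be read in one place. In this assay hydrogen in place of methoxy, on an aromatic carbon ortho to a methoxy group and meta to a large group, gives a number 1 percentage points lower from compound 2 to compound 4 (within the scatter) and methoxy in place of hydrogen gives a number 1 percentage points higher from compound 1 to compound 4 (within the scatter) so neither direction of the change separates the compounds. Compound 1, compound 4 and compound 2 now form a series that changes one methoxy group at a time, and across it the number of methoxy groups on this ring makes no difference that can be read at the single concentration tested, while no measured evidence bears on this result.

On these data alone, whether any other group at this position would give a step beyond the scatter remains open, for instance a hydroxy group, a fluorine atom or a longer chain such as butoxy. As far as these compounds go, with every number close to the top of the scale, it also remains open whether these three compounds would stay together at higher concentrations.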